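The source may report more compounds than this note shows. Statements on the series, on what has been measured and on what is new or still open speak of the compounds shown alone.

Measured so far:
compound 1 `CCCCCCCCCCn1cc(Cn2nc(N)c3c(C(F)(F)F)cc(-c4ccccc4)nc32)nn1` gives 48.7 ug/mL
compound 2 `Cc1ccc(NC(=O)Cn2cc(Cn3nc(N)c4c(C(F)(F)F)cc(-c5ccccc5)nc43)nn2)cc1` gives 41.5 ug/mL
compound 3 `Nc1nn(Cc2cn(CC(=O)Nc3c(F)cccc3F)nn2)c2nc(-c3ccccc3)cc(C(F)(F)F)c12` gives 43.3 ug/mL

In a functional assay on THP-1 cells (Homo sapiens) for cytotoxicity, read by MTT assay, with a stated time of 24 h (a higher number here means a weaker inhibitor, a lower number a stronger inhibitor), compound 3 stands second highest of the three numbers, yet all three sit within the scatter of one another. Compound 4 `Nc1nn(Cc2cn(CC(=O)Nc3ccc(F)cc3Br)nn2)c2nc(-c3ccccc3)cc(C(F)(F)F)c12` differs from compound 3 by 2-bromo-4-fluorophenyl in place of 2,6-difluorophenyl on an amide-type nitrogen. The step that bears most directly on this is a 1.0-fold higher number from compound 2 to compound 3 (0.02 log units; within the scatter), an exchange on the same amide-type nitrogen that left the number essentially unchanged. The steps of a 1.2-fold lower number from compound 1 to compound 2 (0.07 log units; within the scatter) and a 1.1-fold lower number from compound 1 to compound 3 (0.05 log units; within the scatter), which replace the nonyl chain altogether, were likewise within the scatter. Going by the values given here, nothing among the measured compounds suggests the aryl group on the amide nitrogen moves this read-out, so for compound 4 no step beyond the scatter is expected: a 1.0-fold lower number from compound 3 to compound 4 (0.00 log units; within the scatter). Compound 4 is therefore estimated at 43 ug/mL, with a range of 25 ug/mL to 75 ug/mL.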

Compound 4, half-maximal inhibitory concentration: 65.6 ug/mL
For compound 4 the middle estimate is 1.5-fold (0.18 log units) below the measured one; measured number inside the range.
By their numbers in this assay, from the lowest: compounds 2, 3, 1 and 4 (each within the scatter of the next).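

In this assay, going by these compounds alone, bromine appears for the first time in the aryl group on the amide-type nitrogen, and 2-bromo-4-fluorophenyl still keeps the read-out within the scatter: a 1.5-fold higher number from compound 3 to compound 4 (0.18 log units; within the scatter) and a 1.6-fold higher number from compound 2 to compound 4 (0.20 log units; within the scatter). The exchange against the nonyl chain reads the same way, with a 1.3-fold higher number from compound 1 to compound 4 (0.13 log units; within the scatter). No measurement on hand gives a cause for these steps. As far as these compounds go, whether an amine or a carboxylic acid on that aryl ring, or a longer chain in place of nonyl, would carry the number beyond the scatter remains open. The shared core stays unvaried across these compounds.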